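Shortening the chain from compound 2 to compound 4

The compounds below may be only part of what the source reports. "The series", "measured", "known", "first", "only" and "open" are said of these compounds alone.

Measured in a functional assay on MCF7 cells (Homo sapiens) for antiproliferative activity, read by MTT assay, with a stated time of 3 days; on this read-out higher numbers stand for weaker inhibition and lower numbers for stronger inhibition:
compound 1 `O=C1c2ccccc2C(=O)N1C/C=C\Cn1cc(C#Cc2ccc(Br)cc2)c(=O)[nH]c1=O`: > 100000 nM (a limit)
compound 2 `CCCCCCC#Cc1cn(C/C=C/CN2C(=O)c3ccccc3C2=O)c(=O)[nH]c1=O`: 24000 nM
compound 3 `CCCCCc1ccc(C#Cc2cn(C/C=C\CN3C(=O)c4ccccc4C3=O)c(=O)[nH]c2=O)cc1`: > 100000 nM (a limit)

Among the measured compounds shown here, compound 2 gives 24000 nM, the only actual number. The other two readings are not numbers, and the evidence on them is the limit of > 100000 nM in this assay, at which 2 of the 3 values shown sit.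

The next compound to be read is compound 4 `CCCCCC#Cc1cn(C/C=C/CN2C(=O)c3ccccc3C2=O)c(=O)[nH]c1=O`, which has not yet been measured. The structural change is hydrogen in place of methyl on a saturated chain carbon, five bonds along the chain from a triple-bonded carbon.

For the measured compounds named here, the only measured step is a step that the two limits leave unreadable from compound 1 to compound 3, with pentyl in place of bromo on an aromatic carbon. That step offers no size to carry over, and it does not fall on the saturated chain. Going by the values given here, no measured step therefore sizes this change, so in this assay no shift beyond the usual scatter is expected, and no direction can be assigned. The estimated move is a 1.1-fold higher number from compound 2 to compound 4 (0.03 log units; within the scatter). A reading that returns only a limit remains possible. For compound 4 the expected value is 26000 nM, with an estimated range of 10000 nM to 75000 nM.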

Compound 4, half-maximal inhibitory concentration: 44000 nM
The estimate for compound 4 lay 1.7-fold (0.23 log units) below the measured number, and the stated range covers the measured number.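

In this assay the saturated chain now has its first readable step, a 1.8-fold higher number from compound 2 to compound 4 (0.26 log units; within the scatter), for hydrogen in place of methyl on a saturated chain carbon, five bonds along the chain from a triple-bonded carbon. Compound 4 gives the series a second actual number, so a change on this chain can now be sized rather than only estimated, and removing this one carbon keeps the reading within the scatter of compound 2; one pair supports no trend with chain length. Nothing measured in the series speaks to a cause for this step.

Going by these compounds, whether a much shorter chain, a longer chain, or an amine or a hydroxyl group at the chain end would move the number beyond the scatter stays open, as a single step within the scatter cannot settle how far this tolerance extends. Compound 1 and compound 3 are limits and not numbers, and they differ from compound 2 in more than one place, so they size nothing on this chain: the limit of > 100000 nM in this assay, at which 2 of the 4 values shown sit.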